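Methoxy to methyl on the shared core: cytotoxicity in THP-1 cells

The source may hold more compounds than are shown below. What is called first, only, known or untested is meant among the compounds shown, and "the series" means these compounds.

Compound 1 `N#Cc1ccn2c(Nc3ccc(F)cc3)c(-c3ccccn3)nc2c1` gives in an ADME assay on THP-1 cells (Homo sapiens) for cytotoxicity (on this read-out lower numbers stand for higher toxicity in this test and higher numbers for lower toxicity in this test), only a limit, > 50000 nM.
Compound 2 `COc1ccn2c(Nc3ccc(F)cc3)c(-c3ccccn3)nc2c1` gives in this assay the value 4560 nM.

Within the data shown here, compound 2 thus holds the only number in this set; the other value, that of compound 1, is a limit and not a number (the limit of > 50000 nM in this assay, at which 1 of the 2 values shown sits). The step of an at least 10-fold lower number from compound 1 to compound 2 (1.04 log units; beyond the scatter) is large and beyond the scatter. Compound 3 `Cc1ccn2c(Nc3ccc(F)cc3)c(-c3ccccn3)nc2c1` differs from compound 2 by methyl in place of methoxy on an aromatic carbon. Among the measured compounds shown here, the only measured step touches the same aromatic carbon but swaps cyano for methoxy, so it offers no direct guide for methoxy against methyl. With nothing else to go on, the expectation is for no step beyond the scatter in this assay. Compound 3 is therefore estimated at 6000 nM, within 2000 nM to 20000 nM, the expected step being a 1.3-fold higher number from compound 2 to compound 3 (0.12 log units; within the scatter).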

Compound 3, half-maximal cytotoxic concentration: 5900 nM
Compound 3: the middle estimate sits 1.0-fold (0.01 log units) above what was measured; low and high end bracket the measured number.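

In this assay, methoxy and methyl on this aromatic carbon, opposite the ring nitrogen, are not told apart, with a 1.3-fold higher number from compound 2 to compound 3 (0.11 log units; within the scatter) lying within the scatter. The nitrile therefore stands alone among the three groups, since an at least 8.4-fold lower number from compound 1 to compound 3 (0.92 log units; beyond the scatter) now adds a second step beyond the scatter, showing that the separation is not specific to methoxy. That step is only a bound, since its nitrile end is a limit and not a number: the limit of > 50000 nM in this assay, at which 1 of the 3 values shown sits.

The compounds shown leave open whether the nitrile alone separates from the others here, or whether an amine, a carboxylic acid or a longer chain on this carbon would do the same. From the compounds shown here alone, the true size of the gap between the nitrile and the other two groups also stays open.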